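The source may hold more compounds than are shown below. What is called first, only, known or untested is meant among the compounds shown, and "the series" means these compounds.

Of the compounds shown here, three have been measured in an assay on mitochondria (strain BALB/c) for inhibition of glycerol-3-phosphate acyltransferase 1, mitochondrial (Mus musculus), read by scintillation counting, with a stated time of 10 min; on this read-out higher numbers stand for weaker inhibition and lower numbers for stronger inhibition. Compound 1 `CCCCCCCCS(=O)(=O)Nc1cc(-c2cccc(F)c2)ccc1C(=O)O` gives 32600 nM in this assay. Compound 2 `CCCCCCCCS(=O)(=O)Nc1ccc(-c2ccc(Cl)cc2)cc1C(=O)O` gives 9200 nM in this assay. Compound 3 `CCCCCCCCS(=O)(=O)Nc1cc(C(=O)c2ccc(CCCC)cc2)ccc1C(=O)O` gives 15800 nM in this assay. Compound 2 stands at the low end of these three numbers: the gap to compound 3 lies within the usual scatter of repeated measurements, so the two cannot be told apart, while compound 1 gives a higher number that lies beyond the scatter.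

Compound 4 `CCCCCCCCS(=O)(=O)Nc1ccc(C(=O)c2ccc(OC)cc2)cc1C(=O)O` has not yet been measured. It differs from compound 2 in one place: (4-methoxyphenyl)carbonyl in place of 4-chlorophenyl on an aromatic carbon. Within the data shown here, no measured pair in this set shows this exact change, so its effect cannot be read from a shared step. What the data do offer is compound 3, which also carries a carbonyl between the shared core and a second aromatic ring and gives 15800 nM, within the scatter of compound 2.

On that basis, compound 4 is expected to stay close to compound 2, with a step of a 1.5-fold higher number from compound 2 to compound 4 (0.18 log units; within the scatter) that should fall within the scatter rather than beyond it. The estimate for compound 4 in this assay is 14000 nM, with a range from 5000 nM to 40000 nM.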

Compound 4, half-maximal inhibitory concentration: 44300 nM
The estimate for compound 4 lay 3.2-fold (0.50 log units) below the measured number; the measured number lies above the stated range.
By their numbers in this assay, from the lowest: compounds 2 and 3 (each within the scatter of the next); then compounds 1 and 4 (each within the scatter of the next).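

In this assay the exchange of 4-chlorophenyl for (4-methoxyphenyl)carbonyl gives a 4.8-fold higher number from compound 2 to compound 4 (0.68 log units; beyond the scatter) and so weakens inhibition by more than the usual scatter. Among these compounds, this is the first step in the set that can be read directly, and it shows that the number responds to what sits on this aromatic carbon, which is meta to the carboxy group and para to a large group. The data show that the number changes at this position but not why, as nothing measured here speaks to the cause.

The change also alters two things at once, adding a carbonyl and replacing chlorine with a methoxy group, so the compounds shown leave open which of the two carries the step. A (4-chlorophenyl)carbonyl or a plain 4-methoxyphenyl at this same place would separate the two, while a simple amine or a carboxylic acid there would test whether this position needs a second aromatic ring at all.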